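A few compounds are considered here, and "the series" means these few. Any claim that something is new, unique, unknown or untested is made for them only; others in the source may bear on it.

Measured compounds in a functional assay on HEK293 cells for antagonist activity at metabotropic glutamate receptor 5 (Rattus norvegicus), read by calcium flux; on this read-out lower numbers stand for stronger inhibition and higher numbers for weaker inhibition:

- Compound 1, `COc1cccc(Nc2ncnc3ccc(Br)cc23)c1`: > 10000 nM
- Compound 2, `Clc1ccc(CNc2ncnc3ccc(Cl)cc23)cc1`: > 30000 nM
- Compound 3, `Clc1ccc2ncnc(Oc3cccc(Br)c3)c2c1`: 6570 nM

Among the measured compounds shown here, compound 3 is the only member of the set with a numerical reading in this assay. Compound 1 reaches only a limit of the assay, (the limit of > 10000 nM in this assay, at which 1 of the 3 values shown sits). Compound 2 likewise reaches only a limit of the assay, (the limit of > 30000 nM in this assay, at which 1 of the 3 values shown sits). Against these two limits, compound 3 stands as the sole point that can be placed on the scale, and its value sits well inside the measurable window.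

The next compound, compound 4 `Brc1cccc(Oc2ncnc3ccc(Br)cc23)c1`, keeps the ether link and the bromophenyl group of compound 3 and differs in a single halogen swap: bromo in place of chloro on an aromatic carbon. For the measured compounds named here, no step of this kind between two measured compounds is available here, so its size cannot be read from the data. An exchange of one halogen for the neighbouring heavier one, at the same position and with no change in ring count, donors, acceptors or charge, is expected to move the reading little, most likely within the usual scatter, with no clear direction.

Compound 4 is therefore estimated at 5500 nM, within the range 2000 nM to 15000 nM, with an expected step from compound 3 to compound 4 of a 1.2-fold lower number from compound 3 to compound 4 (0.08 log units; within the scatter).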

Compound 4, half-maximal inhibitory concentration: > 10000 nM
Compound 4 ended at the assay's limit (the forecaster's own chance of this, stated with the estimate: 15%); at least 1.8-fold (0.25 log units) between middle value and limit.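

In this assay, among the compounds shown here, the halogen on this aromatic carbon, meta to a fused ring and para to a fused ring, gives the first single-place change that can be read: bromo in place of chloro comes with an at least 1.5-fold higher number from compound 3 to compound 4 (0.18 log units; that floor lies within the scatter). Compound 4 gives > 10000 nM, which is a limit of the assay and not a number, so the step is known only as a floor and its true size stays unread. Compound 3 therefore remains the only compound with a numerical reading, and bromo shows no gain over chloro at this position, the reading of the bromo compound stopping at a limit of the assay: the limit of > 10000 nM in this assay, at which 2 of the 4 values shown sit.

Still open, on these data alone, is how fluoro, methyl, methoxy or nitrile on this carbon would read, and whether any of them would give a lower number than chloro. Steps involving compound 1 and compound 2 cannot be read, so the separate contributions of the ether link and of the groups on the outer ring remain unresolved.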